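The source may hold more compounds than are shown below. What is called first, only, known or untested is meant among the compounds shown, and "the series" means these compounds.

Measured so far:
compound 1 `C=CCn1c(=O)/c(=C\c2ccccc2Cl)[nH]c(=O)/c1=C\c1ccccc1OC`, 4600 nM
compound 2 `C=CCn1c(=O)/c(=C\c2cccc(Br)c2)[nH]c(=O)/c1=C\c1ccccc1OC`, 5900 nM

Both compounds share one core and carry two aromatic rings on it, each on a double-bonded chain carbon bound to an aromatic carbon. In a functional assay on BGC-823 cells (Homo sapiens) for cytotoxicity, read by CCK-8 assay, with a stated time of 72 h (a higher number here means a weaker inhibitor, a lower number a stronger inhibitor), compound 2 gives 5900 nM, the highest of the two numbers, while compound 1 gives 4600 nM; the difference a 1.3-fold higher number from compound 1 to compound 2 (0.11 log units; within the scatter), so the two compounds cannot be told apart.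

Compound 3 `C=CCn1c(=O)/c(=C\c2cccc(Br)c2)[nH]c(=O)/c1=C\c1cccc(Br)c1` differs from compound 2 by 3-bromophenyl in place of 2-methoxyphenyl on a double-bonded chain carbon bound to an aromatic carbon, so that both arms now carry the same 3-bromophenyl group. Among the compounds with values here, the only measured step, the one from compound 1 to compound 2, changed the other arm, exchanging 2-chlorophenyl for 3-bromophenyl, and gave a 1.3-fold higher number from compound 1 to compound 2 (0.11 log units; within the scatter). Within the data shown here, no measurement speaks directly to the 2-methoxyphenyl arm, and the one known step on this core was small. On that basis the step of a 1.0-fold higher number from compound 2 to compound 3 (0.01 log units; within the scatter) is expected to stay within the usual scatter, with no clear direction. Compound 3 is therefore estimated at 6000 nM in this assay, with a range from 2500 nM to 15000 nM.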

Compound 3, half-maximal inhibitory concentration: "not active" (no number reported)
No number was reported for compound 3; no gap can be computed for the estimate.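

Within the data shown here, compound 3 is reported in this assay only as "not active", without a number, and no step from compound 2 to compound 3 can be read from that. No evidence at hand bears on this result. The compounds shown leave open how 3-bromophenyl in place of 2-methoxyphenyl changes the number on the shared core.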